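Anilide Substituent Change and Liver-Cell Toxicity

The source may hold more compounds than are shown below. What is called first, only, known or untested is meant among the compounds shown, and "the series" means these compounds.

Measured in a toxicity assay on HepG2 cells (Homo sapiens) for inhibition, read by CellTiter-Glo, with a stated time of 48 h; a lower number here means a stronger inhibitor, a higher number a weaker inhibitor:
Compound 3 (`COc1ccc2nc(C)cc(OCC(=O)Nc3cccc(C)c3)c2c1`): 39800 nM
Compound 1 (`Cc1cc(C)cc(NC(=O)COc2cc(C)nc3ccc(F)cc23)c1`): 63100 nM
Compound 2 (`COc1ccc2nc(C)cc(OCC(=O)NCc3cc(C)cc(C)c3)c2c1`): > 100000 nM, which is a limit of this assay and not a number.

Compound 3 has the lowest of the two numbers, with compound 1 within the scatter of it. For the measured compounds named here, the one measured step on the amide nitrogen, an at least 2.5-fold lower number from compound 2 to compound 3 (0.40 log units; beyond the scatter), bears on this position, and the limit of > 100000 nM in this assay, at which 1 of the 3 values shown sits, caps how large it may be. Compound 4 (`COc1ccc(NC(=O)COc2cc(C)nc3ccc(OC)cc23)cc1`) carries 4-methoxyphenyl in place of 3-methylphenyl on an amide-type nitrogen. This change keeps the phenyl ring and only alters its substituent, unlike the benzyl-to-phenyl step, so no step beyond the scatter is expected: compound 4 is estimated at 45000 nM (range 15000 nM to 100000 nM), a step of a 1.1-fold higher number from compound 3 to compound 4 (0.05 log units; within the scatter).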

Compound 4, half-maximal inhibitory concentration: > 100000 nM
Compound 4 gave a limit, no number; the forecaster's own chance of this, stated with the estimate: 25%; middle value at least 2.2-fold (0.34 log units) from the limit.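

Even with the phenyl ring kept, the group on it matters at this amide-type nitrogen: 4-methoxyphenyl in place of 3-methylphenyl gives an at least 2.5-fold higher number from compound 3 to compound 4 (0.40 log units; beyond the scatter). For compound 4, > 100000 nM is a limit of the assay and not a number. The step from compound 2 to compound 4 cannot be read, and more of the series now sits at this ceiling: the limit of > 100000 nM in this assay, at which 2 of the 4 values shown sit.

The 3-methylphenyl and 4-methoxyphenyl groups differ in both the substituent and its place on the ring, and the compounds shown do not separate the two. Going by these compounds, how an amine or a carboxylic acid on this ring would read also stays open.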